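Compound 3 loses its aminocyclohexyl group

The compounds below may be only part of what the source reports. "The series", "measured", "known", "first", "only" and "open" are said of these compounds alone.

Among the measured compounds shown here, in an ADME assay on microsomes from liver (Homo sapiens) for metabolic stability, using NADPH, with a stated time of 10 min (a higher number here means that more of the compound is left, a lower number that less of the compound is left), compound 3 `CN(C[C@H]1Cc2c(cccc2N[C@H]2CC[C@H](N)CC2)CN1)[C@H]1CCCc2cccnc21` gives 100% and holds the highest number of the three compounds measured so far. In this assay compound 1 `CN(C[C@H]1Cc2c(cccc2N2C[C@H]3CNC[C@H]3C2)CN1)[C@H]1CCCc2cccnc21` gives 86.7% and compound 2 `CN(C)C1CCN(c2cccc3c2C[C@H](CN(C)[C@H]2CCCc4cccnc42)NC3)CC1` gives 78.4% on the same scale. The next compound, compound 4 `CN1C[C@@H]2CN(c3cccc4c3C[C@H](CN(C)[C@H]3CCCc5cccnc53)NC4)C[C@@H]2C1`, keeps the shared core of compound 3 and changes one group on an aromatic carbon. The change is a group of 9 heavy atoms (7 carbon, 2 nitrogen; 2 five-membered non-aromatic rings with 1 hetero atom each) in place of a group of 8 heavy atoms (6 carbon, 2 nitrogen; one six-membered non-aromatic ring of carbon only), on an aromatic carbon and nothing else differs.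

Compound 1 offers the closest comparison, since it also carries a group with 2 five-membered non-aromatic rings with 1 hetero atom each. Moving away from that group gave a number 13.3 percentage points higher from compound 1 to compound 3 (beyond the scatter) and the change here runs the opposite way, so it points to a lower number. The step of a number 21.6 percentage points higher from compound 2 to compound 3 (beyond the scatter) also leaves compound 3 on top, this time against a group with one six-membered non-aromatic ring. The step of a number 8.3 percentage points lower from compound 1 to compound 2 (within the scatter) shows that the groups of those two compounds are not separated by this measurement. A modest drop beyond the scatter is therefore expected, and the estimated size is a number 19 percentage points lower from compound 3 to compound 4 (beyond the scatter) for this change. Compound 4 is expected to give an estimated 81% within a range of 68% to 94% when it is measured.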

Compound 4, percent of the compound remaining: 100%
Beside the measured number, compound 4's estimate is 19 percentage points below it; measured number above the stated range.
By their numbers in this assay, from the lowest: compounds 2 and 1 (each within the scatter of the next); then compounds 3 and 4 (each within the scatter of the next).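

In this assay, among the compounds shown here, the group with 2 five-membered non-aromatic rings does not itself go with a lower number: the step is a number 13.3 percentage points higher from compound 1 to compound 4 (beyond the scatter), and the only change is methyl in place of hydrogen on an amine nitrogen in a ring. So the earlier gap between this kind of group and (4-aminocyclohexyl)amino depended on that ring nitrogen, as no change at the digits printed from compound 3 to compound 4 (within the scatter) leaves the two groups unseparated on the aromatic carbon, even though the entering group has 0 hydrogen-bond donors and the leaving group has 2. The 4-(dimethylamino)piperidin-1-yl group of compound 2 now stands apart from the methylated group, with a number 21.6 percentage points higher from compound 2 to compound 4 (beyond the scatter), yet no measurement here explains why one methyl or one change of group moves the number.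

As far as these compounds go, whether a larger group on that ring nitrogen, such as ethyl or acetyl, would hold the number remains open. With compound 3 at 100% and compound 4 at 100%, this read-out also cannot show whether a morpholine on the same aromatic carbon would match them.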